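A few compounds are considered here, and "the series" means these few. Any claim that something is new, unique, unknown or untested is made for them only; others in the source may bear on it.

Compound 2 (`CCC[C@H](NC(=O)[C@@H]1C[C@@H]2CN1C(=O)[C@H](C(C)(C)C)NC(=O)OCCCCCCc1cccc3c1CN(C3)C(=O)O2)C(=O)C(=O)CC1CC1`) reads > 50000 nM in an ADME assay on Huh-7 cells (Homo sapiens) for cytotoxicity (a higher number here means that more compound is tolerated, a lower number that less compound is tolerated), and this is a limit of the assay, not a number. Compound 1 (`CCC[C@H](NC(=O)[C@@H]1C[C@@H]2CN1C(=O)[C@H](C(C)(C)C)NC(=O)OCCCCCc1cccc3c1CN(C3)C(=O)O2)C(=O)C(=O)NC1CC1`) reads > 50000 nM in this assay, likewise a limit. Compound 3 (`CCC[C@H](NC(=O)[C@@H]1C[C@@H]2CN1C(=O)[C@H](C1CCCC1)NC(=O)OCCCCCCc1cccc3c1CN(C3)C(=O)O2)C(=O)C(=O)CC1CC1`) reads > 50000 nM in this assay, again a limit. Taken together, the measurements so far amount to the limit of > 50000 nM in this assay, at which 3 of the 3 values shown sit.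

Compound 4 (`CCC[C@H](NC(=O)[C@@H]1C[C@@H]2CN1C(=O)[C@H](C(C)(C)C)NC(=O)OCCCCCCc1cccc3c1CN(C3)C(=O)O2)C(=O)C(=O)NC1CCC1`) keeps compound 2 intact except for one group, with cyclobutylamino in place of cyclopropylmethyl on a carbonyl carbon. For the measured compounds named here, no measured step covers this change. Going by the values given here, the only single-place step available from compound 2 is a step that the two limits leave unreadable from compound 2 to compound 3, which concerns cyclopentyl in place of tert-butyl on a saturated ring carbon. It therefore supplies neither a size nor a direction to carry over.

What remains is the shared behaviour of compound 1, compound 2 and compound 3 in this assay, and on that basis no readable change is expected. Among the compounds with values here, the expected outcome is a number no higher from compound 2 to compound 4 (the limit leaves the size open), with no step anticipated beyond the scatter. Compound 4 is most likely to be reported as a limit again. As a value, the estimate for compound 4 is 50000 nM, with an expected range from 25000 nM to 100000 nM.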

Compound 4, half-maximal cytotoxic concentration: > 50000 nM
Compound 4: no number, only a limit; the forecaster's own chance of this, stated with the estimate: 85%; the middle value sits exactly at the limit.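

Compound 2 and compound 4 are both reported only as a limit in this assay, so no step can be read between them, and the swap of cyclopropylmethyl for cyclobutylamino has no readable size. All the compounds shown share this result: the limit of > 50000 nM in this assay, at which 4 of the 4 values shown sit.

The compounds shown leave open where any of them would actually reach the half-maximal cytotoxic concentration, and whether any of these group changes alters it.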